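A few compounds are considered here, and "the series" means these few. Any claim that something is new, unique, unknown or untested is made for them only; others in the source may bear on it.

Measured so far:
compound 1, `Cc1nc(-c2nc[nH]n2)ccc1-c1cnc2c(n1)N([C@H]1CC[C@@H](O)CC1)C(=O)CN2` — "not determined" (no result reported)
compound 2, `Cc1nc(-c2nc[nH]n2)ccc1-c1cnc2c(n1)N(C(C)C)C(=O)CN2` — 6.97 mL/min/kg

Among the compounds with values here, compound 2 holds the only number in an ADME assay on the whole organism for pharmacokinetics, with Rattus norvegicus as the target, at a dose of 2 mg/kg by the intravenous route; on this read-out higher numbers stand for fast clearance and lower numbers for slow clearance; compound 1 carries no value there, so no step between measured compounds can be read. Compound 3, `CO[C@H]1CC[C@H](N2C(=O)CNc3ncc(-c4ccc(-c5nc[nH]n5)nc4C)nc32)CC1`, differs from compound 2 in one place: 4-methoxycyclohexyl in place of isopropyl on an amide-type nitrogen in a ring. Without a measured step to lean on, the expectation for compound 3 is a modest rise in this assay, of a size around the usual scatter rather than clearly beyond it, giving an expected step of a 1.6-fold higher number from compound 2 to compound 3 (0.20 log units; within the scatter). Compound 3 is therefore estimated at 11 mL/min/kg, with a range from 5 mL/min/kg to 24 mL/min/kg.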

Compound 3, clearance: 16 mL/min/kg
Compound 3: the middle estimate sits 1.5-fold (0.16 log units) below what was measured; the measured number falls inside the stated range.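

In this assay, the amide-type nitrogen in a ring now has its first readable step: 4-methoxycyclohexyl in place of isopropyl gives a 2.3-fold higher number from compound 2 to compound 3 (0.36 log units; beyond the scatter). The read-out therefore responds to a change at this position, although a single step sets no pattern. Nothing at hand bears on the reason for this step. As far as these compounds go, whether the rise goes with the cyclohexyl ring or the methoxy group stays open. Also open, from the compounds shown here alone, is how an amine or a carboxylic acid on that ring, or a longer alkyl chain on the nitrogen, would read.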